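A few compounds are considered here, and "the series" means these few. Any claim that something is new, unique, unknown or untested is made for them only; others in the source may bear on it.

Of the compounds shown here, three sharing one core have been measured in an assay for inhibition of serine/threonine-protein kinase 4 (Homo sapiens), read by luminescence and ADP-Glo, in the presence of a further agent that is not named here; on this read-out higher numbers stand for weaker inhibition and lower numbers for stronger inhibition. Compound 1 `OCCCNc1ncnc2[nH]cc(-c3cccc(Cl)c3)c12` gives 94 nM, compound 2 `CC1(N)CCN(c2ncnc3[nH]cc(-c4cccc(Cl)c4)c23)CC1` gives 163 nM, and compound 3 `Clc1cccc(-c2c[nH]c3ncnc(N4CCCCC4)c23)c1` gives 48 nM. Compound 3 has the lowest of the three numbers, but its gap to compound 1 is within the scatter, a 2.0-fold lower number from compound 1 to compound 3 (0.29 log units; within the scatter), while its gap to compound 2 is beyond it, a 3.4-fold lower number from compound 2 to compound 3 (0.53 log units; beyond the scatter). Compound 4 `CN(C)c1ncnc2[nH]cc(-c3cccc(Cl)c3)c12` is not yet measured; it differs from compound 3 in that (dimethylamino in place of piperidin-1-yl on an aromatic carbon). Within the data shown here, no measured step exchanges piperidin-1-yl for a group with no ring, so the step from compound 3 is only loosely informed by the two steps that end at compound 3, both of which end at the piperidin-1-yl compound with the lowest number. The same core carries three different amines within a narrow span, so the step to compound 4 is expected to be small in this assay, a 1.8-fold higher number from compound 3 to compound 4 (0.25 log units; within the scatter). Compound 4 is therefore estimated at 85 nM, with a range from 35 nM to 200 nM.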

Compound 4, half-maximal inhibitory concentration: 81 nM
For compound 4 the middle estimate is 1.0-fold (0.02 log units) above the measured one, within the range that was stated.
By their numbers in this assay, from the lowest: compounds 3, 4, 1 and 2 (each within the scatter of the next, the first and the last beyond it).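

Exchanging piperidin-1-yl for dimethylamino on this aromatic carbon removes the ring and goes from 6 heavy atoms to 3, yet in this assay this gives a 1.7-fold higher number from compound 3 to compound 4 (0.23 log units; within the scatter) and so does not show that the ring is needed at this position. Among these compounds, the steps of a 1.2-fold lower number from compound 1 to compound 4 (0.06 log units; within the scatter) and a 2.0-fold lower number from compound 2 to compound 4 (0.30 log units; within the scatter) also place compound 4 within the scatter of both other amines, leaving the gap between compound 2 and compound 3 as the only one among the four compounds beyond the scatter. No evidence is available that would explain the size of these steps.

The compounds shown leave open whether an unsubstituted amino group or a morpholin-4-yl ring on this carbon would stay within the same span. They also leave open whether these steps would hold with a methoxy group in place of the chlorine.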